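Urea replacement at the anilide of the sulfonate series

The source may hold more compounds than are shown below. What is called first, only, known or untested is meant among the compounds shown, and "the series" means these compounds.

Two compounds of the series carry numbers in a functional assay on M21 cells (Homo sapiens) for antiproliferative activity, read by sulforhodamine B assay, with a stated time of 48 h; on this read-out lower numbers stand for stronger inhibition and higher numbers for weaker inhibition. Compound 1 `CC(C)C(=O)Nc1ccc(S(=O)(=O)Oc2ccccc2C(C)C)cc1` gives 11000 nM in this assay. Compound 2 `O=C(CCl)Nc1ccc(S(=O)(=O)Oc2ccccc2I)cc1` gives 3900 nM in this assay. Of the two numbers compound 1 holds the higher one, and its distance to compound 2 lies beyond the scatter of repeated measurement. Going by the values given here, no step between measured compounds that differ in a single place is available, so the series offers no measured change to lean on.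

Compound 3 `CC(C)c1ccccc1OS(=O)(=O)c1ccc(NC(=O)NCCCCl)cc1` has not yet been measured. It differs from compound 1 by (3-chloropropyl)amino in place of isopropyl on a carbonyl carbon. A modest downward step is expected, a 1.8-fold lower number from compound 1 to compound 3 (0.26 log units; within the scatter), although a change within the scatter would not surprise. For compound 3 the estimate in this assay is 6000 nM, with a range from 2000 nM to 20000 nM.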

Compound 3, half-maximal inhibitory concentration: 9300 nM
The estimate for compound 3 lay 1.6-fold (0.19 log units) below the measured number; low and high end bracket the measured number.
By their numbers in this assay, from the lowest: compound 2; then compounds 3 and 1 (each within the scatter of the next).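

Replacing isopropyl with (3-chloropropyl)amino on a carbonyl carbon gives the series its first single-place step: in this assay, a 1.2-fold lower number from compound 1 to compound 3 (0.07 log units; within the scatter). The position therefore accepts the change from an anilide to a urea, including the longer chlorine-bearing chain and the added hydrogen-bond donor, with no shift beyond the scatter. This one step cannot separate the contribution of the new nitrogen from that of the chain, and no measurement on hand accounts for the flat result.

On these data alone, it remains open whether the chlorine contributes at all, which a plain propylamino group on the same carbonyl carbon would test. A shorter 2-chloroethylamino group or a carboxylic acid at the end of the chain could also show whether this position ever responds beyond the scatter.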